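The source may hold more compounds than are shown below. What is called first, only, known or untested is meant among the compounds shown, and "the series" means these compounds.

Compound 1, `Cc1ccc(C(=O)NC2CCCCCC2)c(=O)n1Cc1ccc(F)cc1`; in an assay on HEK293 cells for inhibition of Lysophosphatidylserine lipase ABHD12 (Homo sapiens), read by scintillation counting, with stated times of 30 min and 5 min (a lower number here means a stronger inhibitor, a higher number a weaker inhibitor), compound 1 gives > 10000 nM, a limit of the assay and not a number.
Compound 2, `Cc1c(-c2ccc(F)cc2)cc(C(=O)NC2CCCCCC2)c(=O)n1Cc1ccc(F)cc1`; in this assay compound 2 gives 600 nM.
Compound 3, `Cc1c(Cl)cc(C(=O)NC2CCCCCC2)c(=O)n1Cc1ccc(F)cc1`; in this assay compound 3 gives > 10000 nM, again a limit and not a number.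

Compound 3 thus stands at the edge of what this assay resolves, one of two compounds at that edge (the limit of > 10000 nM in this assay, at which 2 of the 3 values shown sit). Going by the values given here, the step that the two limits leave unreadable from compound 1 to compound 3 has a limit at both ends and cannot be read, while an at least 16-fold higher number from compound 2 to compound 3 (1.22 log units; beyond the scatter) shows how far compound 3 lies from the one compound with a measured number. The unmeasured compound 4, `Cc1c(F)cc(C(=O)NC2CCCCCC2)c(=O)n1Cc1ccc(F)cc1`, differs from compound 3 by fluoro in place of chloro on an aromatic carbon. Among the compounds with values here, no measured step exchanges one halogen for another. The nearest comparison is compound 1, which carries hydrogen at that carbon and is itself reported only as a limit. The single large effect seen, an at least 16-fold lower number from compound 1 to compound 2 (1.22 log units; beyond the scatter), comes from a 4-fluorophenyl group rather than from a halogen. Compound 4 is therefore expected to stay at the limit, with an estimated 15000 nM (range 3000 nM to 60000 nM). The expected step is a step that the limit leaves unreadable from compound 3 to compound 4, not beyond the scatter.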

Compound 4, half-maximal inhibitory concentration: > 10000 nM
Compound 4: a limit, no number (the forecaster's own chance of this, stated with the estimate: 80%); the middle value lies beyond the limit too.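

With fluoro on this carbon, ortho to a methyl group, compound 4 sits at a limit of this assay, as do compound 3 with chloro and compound 1 with hydrogen, so neither halogen tried here gives a measured number: the limit of > 10000 nM in this assay, at which 3 of the 4 values shown sit.

Of the groups shown at this position, only 4-fluorophenyl gives a number, and replacing it with fluoro produces an at least 16-fold higher number from compound 2 to compound 4 (1.22 log units; beyond the scatter), the same readable size as the step to the chloro compound.

The steps among compound 1, compound 3 and compound 4 cannot be read, so any difference between fluoro, chloro and hydrogen here remains hidden.

Going by these compounds, it remains open whether a plain phenyl, a pyridyl, a cyclopropyl or a methoxy group at this carbon would also give a measured number. On these data alone, it is also open whether the 4-fluoro substituent on the phenyl group of compound 2 contributes to its value.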